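The source may report more compounds than this note shows. Statements on the series, on what has been measured and on what is new or still open speak of the compounds shown alone.

Measured so far in a functional assay on the whole organism for inhibition, with Rattus norvegicus as the target, with a stated time of 1 h; on this read-out lower numbers stand for an effect already at smaller amounts and higher numbers for an effect only at larger amounts of compound:
Compound 1, `Cc1nc2c(/C=C/c3ccccc3)cccn2c1C`: 10.4 mg/kg
Compound 2, `Cc1nc2c(/C=C/c3ccccc3)cccn2c1N`: 13 mg/kg
Compound 3, `Cc1nc2c(C/C=C\c3ccccc3)cccn2c1C`: 5.5 mg/kg

Compound 4, `Cc1nc2c(C/C=C\c3ccccc3)cccn2c1N`, has not yet been measured in this assay. It is related to compound 3 by amino in place of methyl on an aromatic carbon, the same change that turns compound 1 into compound 2, namely (amino in place of methyl on an aromatic carbon). How the core of compound 3 differs from that of compound 1 is not broken down here; the gap between compound 1 and compound 3 lies within the scatter, that between compound 2 and compound 3 just beyond it. Among the compounds with values here, the one measured step of this change, a 1.3-fold higher number from compound 1 to compound 2 (0.10 log units; within the scatter), is small. On that basis the step from compound 3 to compound 4 is expected to be a 1.3-fold higher number from compound 3 to compound 4 (0.10 log units; within the scatter). Compound 4 is therefore estimated at 7 mg/kg, with a range of 3.5 mg/kg to 14 mg/kg expected.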

Compound 4, dose for half-maximal effect: 6.4 mg/kg
Estimate against measurement, compound 4: 1.1-fold (0.04 log units) above; the measured number falls inside the stated range.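

In this assay, amino in place of methyl on an aromatic carbon gives a 1.2-fold higher number from compound 3 to compound 4 (0.07 log units; within the scatter), and this new step sits close to the earlier one on the other core: the same change on two cores in this assay, a 1.3-fold higher number (0.10 log units; within the scatter) from compound 1 to compound 2 and a 1.2-fold higher number (0.07 log units; within the scatter) from compound 3 to compound 4, 1.1-fold (0.03 log units) apart, within the scatter of two such steps.
So on these two cores the change reads the same, and on neither does it carry the number beyond the scatter. This rests on two pairs only: it shows that a step too small to separate from the scatter recurs, not that a sizeable effect transfers, and it says nothing about any further core.

The compounds shown leave open what other groups in this place would give, such as a dimethylamino group, a hydroxyl or an ethyl chain. On these data alone, whether any of these would produce a step beyond the scatter on either core remains unknown.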